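A few compounds are considered here, and "the series" means these few. Any claim that something is new, unique, unknown or untested is made for them only; others in the source may bear on it.

Measured in a functional assay on the whole organism with Mus musculus as the target; on this read-out higher numbers stand for an effect only at larger amounts of compound and lower numbers for an effect already at smaller amounts:
Compound 1 `c1ccn(Nc2ccncc2)c1`: > 20 mg/kg
Compound 2 `CN(c1ccncc1)n1cccc1`: > 20 mg/kg
Compound 3 `Clc1cccn1Nc1ccncc1`: > 20 mg/kg

Compound 3 gives > 20 mg/kg, which is a limit and not a number. Its place is the limit of > 20 mg/kg in this assay, at which 3 of the 3 values shown sit, so the measured compounds cannot be ranked. Compound 4 `CCN(c1ccncc1)n1cccc1Cl` differs from compound 3 by ethyl in place of hydrogen on a nitrogen on an aromatic ring. Among the measured compounds shown here, two measured steps bear on this change. The methyl change on such a nitrogen gives a step that the two limits leave unreadable from compound 1 to compound 2. The chloro change, which compound 4 keeps, gives a step that the two limits leave unreadable from compound 1 to compound 3. Neither step has a readable size, so no firm direction can be expected in this assay. The step estimated here is a number no higher from compound 3 to compound 4 (the limit leaves the size open), and it is expected to be small and uncertain. Compound 4 is expected at 20 mg/kg, with an estimated range from 6 mg/kg to 60 mg/kg.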

Compound 4, dose for half-maximal effect: > 20 mg/kg
Compound 4 gave a limit, no number (the forecaster's own chance of this, stated with the estimate: 60%); the middle value sits exactly at the limit.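

Compound 3 and compound 4 both give a limit and not a number, so no step between them can be read: the limit of > 20 mg/kg in this assay, at which 4 of the 4 values shown sit.

The compounds shown leave open whether any of these changes alters the result in this assay at all.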